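Hydroxamate series: amide nitrogen change toward compound 4

A few compounds are considered here, and "the series" means these few. Any claim that something is new, unique, unknown or untested is made for them only; others in the source may bear on it.

Measured in a functional assay on NFF cells (Homo sapiens) for antiproliferative activity; a lower number here means a stronger inhibitor, a higher number a weaker inhibitor:
compound 1 `O=C(/C=C/c1ccccc1)N[C@@H](CCCCCC(=O)NO)C(=O)NCc1ccccc1` gives 4010 nM
compound 2 `O=C(CCCCC[C@H](NC(=O)OCc1ccccc1)C(=O)NCc1ccccc1)NO` gives 1520 nM
compound 3 `O=C(CCCCC[C@H](NC(=O)c1ccc(C(F)(F)F)cc1)C(=O)NCc1ccccc1)NO` gives 1610 nM

Compound 2 has the lowest number of the three in this assay, though compound 3 sits within the scatter of it (a 1.1-fold higher number from compound 2 to compound 3 (0.02 log units; within the scatter)); only compound 1 lies clearly apart (a 2.6-fold lower number from compound 1 to compound 2 (0.42 log units; beyond the scatter), a 2.5-fold lower number from compound 1 to compound 3 (0.40 log units; beyond the scatter)). Compound 4 `O=C(CCCCC[C@H](NC(=O)OCc1ccccc1)C(=O)NC1CCCc2ccccc21)NO` differs from compound 2 at the other end of the molecule: 1,2,3,4-tetrahydronaphthalen-1-yl in place of benzyl on an amide-type nitrogen. Every measured step concerns the group on the carbonyl carbon, so none bears on this change, and the data give no direction for it. The expectation is therefore a step of a 1.0-fold lower number from compound 2 to compound 4 (0.01 log units; within the scatter), within the scatter, with a wide range. Compound 4 is estimated at 1500 nM, between 500 nM and 4500 nM.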

Compound 4, half-maximal inhibitory concentration: 1700 nM
For compound 4 the middle estimate is 1.1-fold (0.05 log units) below the measured one, within the range that was stated.
By their numbers in this assay, from the lowest: compounds 2, 3 and 4 (each within the scatter of the next); then compound 1.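

Swapping benzyl for 1,2,3,4-tetrahydronaphthalen-1-yl on the amide-type nitrogen gives the first reading at this end of the molecule: in this assay there is a 1.1-fold higher number from compound 2 to compound 4 (0.05 log units; within the scatter). The larger carbon group, with 10 heavy atoms against 7 and an added non-aromatic ring, therefore leaves the number within the scatter. Nothing at hand accounts for this result.

Still open, from the compounds shown here alone, is whether a carboxylic acid or an amine on the benzyl group, or a small methyl on this nitrogen, would move the number beyond the scatter. Also open, going by these compounds, is how 1,2,3,4-tetrahydronaphthalen-1-yl reads alongside 4-(trifluoromethyl)phenyl on the carbonyl carbon.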